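The compounds below may be only part of what the source reports. "The series", "measured", "known", "first", "only" and "open" are said of these compounds alone.

Measured compounds:
Compound 1, `CC(C)C[C@H](N)CN(C(=O)[C@@H]1C[C@H]1c1ccccc1)c1ccc(-c2ccccc2)cc1`, gives 880 nM in a functional assay for agonist activity at G protein-coupled receptor 88 (Homo sapiens), read by HTRF and cAMP accumulation; on this read-out higher numbers stand for an effect only at larger amounts of compound and lower numbers for an effect already at smaller amounts.
Compound 2, `CC[C@H](C)[C@@H](CN(C(=O)[C@@H]1C[C@H]1c1ccccc1)c1ccc(-c2ccccc2)cc1)NC(C)=O`, gives 5.8 nM in this assay.
Compound 3, `O=C([C@@H]1C[C@H]1c1ccccc1)N(CCNCC1CCCC1)c1ccc(-c2ccccc2)cc1`, gives 2.5 nM in this assay.

Among these three numbers compound 1 stands highest. Its nearest neighbour is compound 2, reached by a 150-fold lower number from compound 1 to compound 2 (2.18 log units; beyond the scatter), and its furthest is compound 3, reached by a 350-fold lower number from compound 1 to compound 3 (2.55 log units; beyond the scatter). Between the two lower numbers the gap is smaller: a 2.3-fold lower number from compound 2 to compound 3 (0.37 log units; beyond the scatter).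

Compound 4, `CC(C)C[C@H](N)CN(C(=O)[C@@H]1C[C@H]1c1ccccc1)c1ccc(C2=CCCC2)cc1`, differs from compound 1 in one place: cyclopent-1-en-1-yl in place of phenyl on an aromatic carbon. Among the measured compounds shown here, none of the measured steps touches this part of the molecule. All three of them alter the group on the saturated chain carbon bound to the amide-type nitrogen, and in every measured compound the phenyl on the aromatic carbon is kept. The measured steps therefore offer no direct guide to the size or direction of the change from compound 1 to compound 4 in this assay, and the expectation rests only on the fact that the remainder of the structure is unchanged. A step of modest size, in either direction, or none beyond the scatter is expected.

On that basis compound 4 is estimated to give 1500 nM in this assay, with a range from 300 nM to 8000 nM. This estimate is expected to correspond to a 1.7-fold higher number from compound 1 to compound 4 (0.23 log units; within the scatter).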

Compound 4, half-maximal effective concentration: 1200 nM
The estimate for compound 4 lay 1.3-fold (0.10 log units) above the measured number; the measured number falls inside the stated range.
By their numbers in this assay, from the lowest: compound 3; then compound 2; then compounds 1 and 4 (each within the scatter of the next).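

In this assay, putting cyclopent-1-en-1-yl in place of phenyl on an aromatic carbon, para to a large group, gives a 1.4-fold higher number from compound 1 to compound 4 (0.13 log units; within the scatter) and so leaves the two compounds indistinguishable on this read-out. Among the compounds shown here, this is the first look at this position, since every earlier compound kept the phenyl, and it shows that with the 1-amino-3-methylbutyl group on the chain, a six-membered aromatic ring of carbon only is not needed here: a five-membered non-aromatic ring of carbon only with a double bond serves equally well. No supporting data are available that would account for this result.

The compounds shown leave open whether the same exchange would be tolerated alongside the 1-acetamido-2-methylbutyl group of compound 2 or the ((cyclopentylmethyl)amino)methyl group of compound 3, where the numbers are far lower and a change at this position might be easier to see. They also leave open how this position would respond to a fully saturated cyclopentyl ring, a pyridine ring, or a small group such as methyl or chlorine.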